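Adding a cyano group to compound 1

The compounds below may be only part of what the source reports. "The series", "measured", "known", "first", "only" and "open" are said of these compounds alone.

Measured in an ADME assay on a cell-free system (plasma, Homo sapiens); a higher number here means a larger unbound share of the compound, a lower number a smaller unbound share:
Compound 1 `CCNC(=O)Nc1nc2cc(-c3cccnc3)c(=O)n(C(C)C)c2s1`: 0.21
Compound 2 `CCNC(=O)Nc1nc2cc(-c3cccnc3)c(=O)n(CC3CCCCC3)c2s1`: 0.02
Compound 3 `CCNC(=O)Nc1nc2cc(-c3cccnc3)c(=O)n(CC3CCOCC3)c2s1`: 0.14

Two steps place compound 1: a 1.5-fold lower number from compound 1 to compound 3 (0.18 log units; within the scatter), which leaves that pair level, and an 11-fold lower number from compound 1 to compound 2 (1.02 log units; beyond the scatter). Compound 4 `CCNC(=O)Nc1nc2cc(-c3ccc(C#N)nc3)c(=O)n(C(C)C)c2s1` keeps the isopropyl group and turns pyridin-3-yl into 6-cyanopyridin-3-yl: cyano in place of hydrogen on an aromatic carbon. Within the data shown here, all the measured steps, including a 7.0-fold higher number from compound 2 to compound 3 (0.85 log units; beyond the scatter), change the group on the aromatic nitrogen, and none touches this pyridine ring. They therefore give no direct size for the new change. In this assay, a step within the scatter, if anything toward a smaller number, is expected. The estimated step is a 1.3-fold lower number from compound 1 to compound 4 (0.12 log units; within the scatter). For compound 4 the estimated value is 0.16, with an expected range from 0.07 to 0.3.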

Compound 4, unbound fraction: 0.04
Compound 4: middle estimate off by 4.0-fold (0.60 log units), on the high side; measured number outside the range, below it.
By their numbers in this assay, from the lowest: compounds 2 and 4 (each within the scatter of the next); then compounds 3 and 1 (each within the scatter of the next).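

Among these compounds, the pyridine ring, which no earlier step touched, turns out to matter in this assay: cyano in place of hydrogen gives a 5.3-fold lower number from compound 1 to compound 4 (0.72 log units; beyond the scatter). So a group of just 2 heavy atoms, on an aromatic carbon next to the ring nitrogen, moves the unbound share beyond the scatter, as the change on the aromatic nitrogen in compound 2 also did. Nothing available explains this drop.

On these data alone, whether a fluorine atom, a methyl group or a primary amide on this carbon would lower the number as well remains open. So does whether cyano has the same effect with cyclohexylmethyl or (oxan-4-yl)methyl on the aromatic nitrogen.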